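Aryl swap at the imine carbon: cytotoxicity working notes

The source may hold more compounds than are shown below. What is called first, only, known or untested is meant among the compounds shown, and "the series" means these compounds.

compound 1, `CS(=O)(=O)c1ccc(Cc2nnc3n2N=C(c2ccc(-c4ccccc4)cc2)CS3)cc1`: 60.2%
compound 2, `CS(=O)(=O)c1ccc(Cc2nnc3n2N=C(c2cc(Cl)sc2S(N)(=O)=O)CS3)cc1`: 18.7%
compound 3, `CS(=O)(=O)c1ccc(Cc2nnc3n2N=C(c2cc(Cl)sc2Cl)CS3)cc1`: "not active" (no number reported), no number reported

In a functional assay on RAW264.7 cells (Mus musculus) for cytotoxicity, read by MTT assay, with a stated time of 48 h, tested at 25 uM (a higher number here means a stronger effect of the compound at the concentration tested, a lower number a weaker effect), compound 1 gives 60.2% and compound 2 gives 18.7%. Among the measured compounds shown here, compound 3 is recorded as "not active" (no number reported) without a number, so it stands apart from the other two and no numeric step can be drawn to it. Compound 4, `CS(=O)(=O)c1ccc(Cc2nnc3n2N=C(c2ccc(O)c(C(N)=O)c2)CS3)cc1`, is not yet measured. It differs from compound 3 in one place: 3-carbamoyl-4-hydroxyphenyl in place of 2,5-dichlorothiophen-3-yl on a carbon with a double bond to nitrogen. For the measured compounds named here, no measured pair differing in one place is available, so the size of the step from compound 3 to compound 4 is open; a rise beyond the scatter is expected, though a further report of no number remains a real possibility. Compound 4 is estimated at 22% in this assay, within 5% to 45%.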

Compound 4, a percentage reported as activity, at one concentration (the size of the read-out at that concentration, not a potency): 24.7%
The estimate for compound 4 lay 2.7 percentage points below the measured number; the range from low to high includes it.
By their numbers in this assay, from the lowest: compounds 2 and 4 (each within the scatter of the next); then compound 1.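

In this assay, a change of aryl group on the carbon with a double bond to nitrogen gives a number 6 percentage points higher from compound 2 to compound 4 (within the scatter) and so separates these two substituted aryl groups by no more than the scatter. Compound 4 gives 24.7% with a six-membered aromatic ring of carbon only, while compound 3 has no number, so the thiophene of compound 3 cannot be placed against it. Nothing on hand explains these readings.

Open, going by these compounds, is where a plain phenyl at this carbon would fall, and whether a carboxylic acid in place of the carbamoyl group of compound 4 would alter the read-out.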